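This account rests on a few compounds, and the source may have more. Where it says the series, first, only, none or still open, it means among the compounds named here.

Measured so far:
compound 1 `O=C(Nc1ccc(Oc2ncnc3[nH]ncc23)cc1)Nc1ccc(C(F)(F)F)cc1`: 1200 nM
compound 2 `Cn1ncc2c(Oc3ccc(NC(=O)Nc4ccc(C(F)(F)F)cc4)cc3)ncnc21`: > 100000 nM
compound 3 `O=C(Nc1ccc(Oc2ncnc3[nH]ncc23)cc1)c1ccc(Br)cc1`: 74700 nM

In an assay on isolated protein for inhibition of vascular endothelial growth factor receptor 2 (Danio rerio), read by fluorescence and microscopy, with a stated time of 33 h (on this read-out lower numbers stand for stronger inhibition and higher numbers for weaker inhibition), compound 1 gives 1200 nM. For compound 2 the read-out is only a limit of this assay, > 100000 nM. Compound 3 gives 74700 nM, the highest of the two numbers shown, a higher number than compound 1 and so a weaker inhibitor.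

Among the compounds with values here, the only measured single change is an at least 83-fold higher number from compound 1 to compound 2 (1.92 log units; beyond the scatter); its read-out sits at the limit (the limit of > 100000 nM in this assay, at which 1 of the 3 values shown sits). This step touches the shared core and not the chain that carries the carbonyl, so it says nothing direct about the change now in question.

Compound 4 `O=C(Nc1ccc(Oc2ncnc3[nH]ncc23)cc1)NC1CCCCC1` differs from compound 3 by cyclohexylamino in place of 4-bromophenyl on a carbonyl carbon. Compound 3 and compound 1 share everything but this chain: compound 1 carries an aryl urea and gives the lower number, compound 3 an amide and the higher one. Within the data shown here, compound 4 returns to a urea, but with a saturated ring instead of the aryl group, and no measured pair shows that exchange, so the size of the expected change is uncertain. Compound 4 is expected to give about 8000 nM, within 1500 nM to 50000 nM. This expected step is a 9.3-fold lower number from compound 3 to compound 4 (0.97 log units; beyond the scatter).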

Compound 4, half-maximal inhibitory concentration: > 100000 nM
Compound 4 ended at the assay's limit; the forecaster's own chance of this, stated with the estimate: 5%; middle value at least 12-fold (1.09 log units) away from the limit.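

In this assay compound 4 gives > 100000 nM, which is a limit of the assay and not a number. Within the urea series, the exchange of an aromatic ring for a saturated ring is a heavy loss, with an at least 83-fold higher number from compound 1 to compound 4 (1.92 log units; beyond the scatter), so the urea link alone does not carry the read-out of compound 1. Against the amide, the result is less informative: the step is an at least 1.3-fold higher number from compound 3 to compound 4 (0.12 log units; that floor lies within the scatter), and it cannot be read as a change, so this exchange on the carbonyl carbon shows neither a gain nor a loss.

How far compound 4 lies past the end of the read-out stays unknown, because the measurement stops there: the limit of > 100000 nM in this assay, at which 2 of the 4 values shown sit.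

Also open, as far as these compounds go, is whether the urea needs an aromatic ring as such or the 4-(trifluoromethyl)phenyl group in particular, and a plain phenyl ring, a pyridine ring or a short ethyl chain on the same urea nitrogen would help separate these possibilities.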